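Halogen exchange and an ester-to-acid, methoxy swap

A few compounds are considered here, and "the series" means these few. Any claim that something is new, unique, unknown or untested is made for them only; others in the source may bear on it.

Compound 2 `COC(=O)C(Nc1cc(CS(=O)(=O)/C=C/c2c(OC)cc(OC)cc2OC)ccc1OC)c1ccc(Br)cc1` gives the lowest of the two numbers in a functional assay on DU-145 cells (Homo sapiens) for cytotoxicity, read by trypan blue exclusion, with a stated time of 96 h (a higher number here means a weaker inhibitor, a lower number a stronger inhibitor), where compound 2 gives 300 nM; compound 1 `COC(=O)C(Nc1cc(CS(=O)(=O)/C=C/c2c(OC)cc(OC)cc2OC)ccc1OC)c1ccc(Cl)cc1` gives 400 nM, and a 1.3-fold lower number from compound 1 to compound 2 (0.12 log units; within the scatter) separates them. Compound 3 `COc1ccc(C(Nc2cc(CS(=O)(=O)/C=C/c3c(OC)cc(OC)cc3OC)ccc2OC)C(=O)O)cc1` differs from compound 2 by carboxy(4-methoxyphenyl)methyl in place of (4-bromophenyl)(methoxycarbonyl)methyl on a nitrogen on an aromatic ring. Among the measured compounds shown here, no measured step touches either the ester or the halogen-to-methoxy exchange; the only step in hand is the halogen swap, which stayed within the scatter. The estimate for compound 3 therefore rests on a wide range, and the expected step is a 4.0-fold higher number from compound 2 to compound 3 (0.60 log units; beyond the scatter). Compound 3 is expected to give 1200 nM, between 300 nM and 6000 nM.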

Compound 3, half-maximal inhibitory concentration: 100 nM
For compound 3 the middle estimate is 12-fold (1.08 log units) above the measured one, and the stated range ends above it.
By their numbers in this assay, from the lowest: compound 3; then compounds 2 and 1 (each within the scatter of the next).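

At the group on a nitrogen on an aromatic ring, this assay records a 3.0-fold lower number from compound 2 to compound 3 (0.48 log units; beyond the scatter) and a 4.0-fold lower number from compound 1 to compound 3 (0.60 log units; beyond the scatter) for the change to carboxy(4-methoxyphenyl)methyl, so this place can move the number beyond the scatter, which the halogen swap did not. The carboxy and 4-methoxyphenyl parts enter together, and the step belongs to the pair. Nothing available bears on the cause of this step.

Which part carries the step stays open, as the carboxy group with 4-bromophenyl, or methoxycarbonyl with 4-methoxyphenyl, would separate them. Also open, going by these compounds, is how a primary amide in place of the carboxy group would read.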